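A few compounds are considered here, and "the series" means these few. Any claim that something is new, unique, unknown or untested is made for them only; others in the source may bear on it.

Measured in an ADME assay on Vero cells (Chlorocebus sabaeus) for cytotoxicity, read by neutral red uptake, with a stated time of 48 h; a higher number here means a weaker inhibitor, a lower number a stronger inhibitor:
Compound 1 `CN(C)c1nc(Cl)nc2c1ncn2CCNc1ccnc2cc(Cl)ccc12`: > 11800 nM, a limit.
Compound 2 `Clc1ccc2c(NCCn3cnc4c(N5CCCCC5)nc(Cl)nc43)ccnc2c1`: > 10700 nM, a limit.
Compound 3 `Clc1ccc2c(NCCCn3cnc4c(N5CCCC5)nc(Cl)nc43)ccnc2c1`: > 10700 nM, a limit.

Compound 3 has no number of its own, only the limit shared by two of the three compounds, (the limit of > 10700 nM in this assay, at which 2 of the 3 values shown sit). Compound 4 `Clc1ccc2c(NCCCn3cnc4c(N5CCN(c6ccccc6)CC5)nc(Cl)nc43)ccnc2c1` carries 4-phenylpiperazin-1-yl in place of pyrrolidin-1-yl on an aromatic carbon. Among the measured compounds shown here, the one measured step that bears on this is also an exchange on an aromatic carbon, a step that the two limits leave unreadable from compound 1 to compound 2, and it gives no size to carry over. In this assay no step beyond the scatter is therefore expected, and no direction can be read. The expected change is an at least 1.1-fold lower number from compound 3 to compound 4 (0.07 log units; that floor lies within the scatter). Compound 4 is estimated at 9000 nM, with an expected range of 3500 nM to 20000 nM.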

Compound 4, half-maximal inhibitory concentration: > 8900 nM
Compound 4 was reported as a limit (the forecaster's own chance of this, stated with the estimate: 60%); the middle value lies beyond the limit too.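

In this assay, compound 3 and compound 4 are both reported only as limits, so the step between them cannot be read. The compounds shown all carry limits, leaving open whether any exchange on that aromatic carbon changes the read-out at all.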